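Cyclobutylmethyl ester on the furan-3-yl core

This account rests on a few compounds, and the source may have more. Where it says the series, first, only, none or still open, it means among the compounds named here.

Compound 1 `CC1=C(C(=O)OCC2CC2)C(c2ccco2)NC(=O)N1` carries a cyclopropylmethyl ester and a furan-2-yl group. In an assay on membranes from HeLa cells for displacement of a labelled ligand from adenosine receptor A3 (Homo sapiens), read by scintillation counting, with a stated time of 180 min, tested at 1 uM (a lower number here means less inhibition, a higher number more inhibition at the concentration tested (going by the name of the read-out)), compound 1 gives 1%. Compound 2 `CC1=C(C(=O)OCC2CCC2)C(c2ccco2)NC(=O)N1` differs from compound 1 by cyclobutyl in place of cyclopropyl on a saturated chain carbon bound to an oxygen next to a carbonyl group, and compound 2 gives 1%; the step is no change at the digits printed from compound 1 to compound 2 (within the scatter). Compound 3 `CC1=C(C(=O)OCC2CC2)C(c2ccoc2)NC(=O)N1` differs from compound 1 by furan-3-yl in place of furan-2-yl on a saturated ring carbon; compound 3 gives 3%, a step of a number 2 percentage points higher from compound 1 to compound 3 (within the scatter). The three values lie within the scatter of one another, so no ordering among them is claimed.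

Compound 4 `CC1=C(C(=O)OCC2CCC2)C(c2ccoc2)NC(=O)N1` has not been measured. It differs from compound 3 by cyclobutyl in place of cyclopropyl on a saturated chain carbon bound to an oxygen next to a carbonyl group. The place of this change is the same, word for word, as the place of the change from compound 1 to compound 2, so the two are taken as the same change; it occurs twice among these compounds. The step from compound 3 to compound 4 in this assay is expected to be no change at the digits printed from compound 3 to compound 4 (within the scatter), which rests on the measured step of no change at the digits printed from compound 1 to compound 2 (within the scatter) on the furan-2-yl core. Compound 4 is estimated at 3%, with a range from 0% to 12%.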

Compound 4, a percentage reported as inhibition, at one concentration (the size of the read-out at that concentration, not a potency): 2%
The estimate for compound 4 lay 1 percentage points above the measured number, and the stated range covers the measured number.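

In this assay, the cyclobutyl for cyclopropyl change gives a number 1 percentage points lower from compound 3 to compound 4 (within the scatter), and this agrees with its earlier reading on the core of compound 1: the same change on two cores in this assay, no change at the digits printed (within the scatter) from compound 1 to compound 2 and a number 1 percentage points lower (within the scatter) from compound 3 to compound 4, 1 percentage points apart, within the scatter of two such steps

The furan-3-yl for furan-2-yl change, read on the cyclobutylmethyl ester, gives a number 1 percentage points higher from compound 2 to compound 4 (within the scatter), and this also agrees with its earlier reading: the same change on two cores in this assay, a number 2 percentage points higher (within the scatter) from compound 1 to compound 3 and a number 1 percentage points higher (within the scatter) from compound 2 to compound 4, 1 percentage points apart, within the scatter of two such steps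

This shows only that neither change moves the read-out beyond the scatter among these four compounds; it does not show that either change would behave alike on a compound with a larger reading, and a reading at one concentration gives no potency.

Left open is whether a longer chain or a phenyl ring on the ester, or an amine or a carboxylic acid in place of the furan ring, would give a reading beyond the scatter of these four. Also open, from the compounds shown here alone, is how the series reads at any other concentration.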